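Amino for Methoxy on a Second Core: Cytotoxicity Outlook

A few compounds are considered here, and "the series" means these few. Any claim that something is new, unique, unknown or untested is made for them only; others in the source may bear on it.

Compound 1, `COc1ncnc(Nc2ccc(Cl)c(OCC=C(C)C)c2)n1`, gives 18000 nM in an ADME assay on MT2 cells (Homo sapiens) for cytotoxicity; a higher number here means that more compound is tolerated, a lower number that less compound is tolerated.
Compound 2, `CC(C)=CCOc1cc(Nc2ncnc(N)n2)ccc1Cl`, gives 48000 nM in this assay.
Compound 3, `COc1cc(OC)nc(Nc2ccc(Cl)c(OCC=C(C)C)c2)n1`, gives 28000 nM in this assay.

All three share the same chlorinated aryl ether side, differing in the ring to which it is attached. Among the compounds with values here, the step of a 2.7-fold higher number from compound 1 to compound 2 (0.43 log units; beyond the scatter) is the one measured change of a single group; its nature is amino in place of methoxy on an aromatic carbon. Compound 3 carries a different core from compound 1, and the difference between the two cores is not broken down here. In this assay the values of compound 1 and compound 3 lie within the scatter of each other, as do those of compound 3 and compound 2.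

Compound 4, `COc1cc(N)nc(Nc2ccc(Cl)c(OCC=C(C)C)c2)n1`, has not been measured. It differs from compound 3 by amino in place of methoxy on an aromatic carbon. This is the same kind of change as from compound 1 to compound 2, but not the same: there the ring had 3 nitrogen and the carbon sat between two ring nitrogen atoms, whereas here the ring has 2 nitrogen, the carbon sits next to the ring nitrogen and meta to a methoxy group (2 heavy atoms).

For compound 4 in this assay a step of about a 2.1-fold higher number from compound 3 to compound 4 (0.33 log units; beyond the scatter) is expected, resting on the step of a 2.7-fold higher number from compound 1 to compound 2 (0.43 log units; beyond the scatter). The surroundings of the two changes differ, and the expected step is kept smaller than the measured one. Compound 4 is estimated at 60000 nM, between 25000 nM and 150000 nM.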

Compound 4, half-maximal cytotoxic concentration: 19000 nM
Compound 4: middle estimate off by 3.2-fold (0.50 log units), on the high side; measured number below the stated range.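

On the core of compound 3, amino in place of methoxy gives a 1.5-fold lower number from compound 3 to compound 4 (0.17 log units; within the scatter) in this assay, so on this core the swap cannot be told apart from the ordinary spread of repeated measurements. Set beside the same swap on the core of compound 1, this result shows that the change does not carry over as one fixed step, and a step measured on one core is a poor guide to the other in this series: the same change on two cores in this assay, a 2.7-fold higher number (0.43 log units; beyond the scatter) from compound 1 to compound 2 and a 1.5-fold lower number (0.17 log units; within the scatter) from compound 3 to compound 4, 3.9-fold (0.59 log units) apart, beyond the scatter of two such steps

Within the data shown here, what this does not show is why the two cores respond differently, since each core offers only a single pair, and the cores differ in their ring nitrogen count and in the methoxy group that compound 3 and compound 4 keep, so no single feature can be singled out.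

The compounds shown leave open how a methylamino group or a hydroxyl group would fare in place of the methoxy group on either core, and what the swap would do on a third core. They also leave open whether the amino-for-methoxy step would look the same if a shorter chain, such as an ethyl group, replaced the chain on the ether oxygen.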